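Fluoro in Place of Methoxy on a Shared Core

The compounds below may be only part of what the source reports. "The series", "measured", "known", "first", "only" and "open" are said of these compounds alone.

Compound 1 `COc1ccc(-n2cc(CN3C(=O)C[C@@H]4CC[C@@]3(C)C4(C)C)nn2)cc1` was tested in a functional assay on OVCAR-3 cells (Homo sapiens) for inhibition, read by MTT assay, with a stated time of 24 h (a higher number here means a weaker inhibitor, a lower number a stronger inhibitor), where compound 1 gives 250 nM. Of the two numbers in hand, compound 1 stands highest; its nearest neighbour is compound 2 `CC1(C)[C@H]2CC[C@]1(C)N(Cc1cn(-c3ccccc3Br)nn1)C(=O)C2`, which in this assay gives 140 nM. Among the compounds with values here, the only measured step, a 1.8-fold lower number from compound 1 to compound 2 (0.25 log units; within the scatter), exchanges the group on the aromatic nitrogen and stays within the scatter, so the two compounds cannot be ranked against each other.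

Compound 3 `CC1(C)[C@H]2CC[C@]1(C)N(Cc1cn(-c3ccc(F)cc3)nn1)C(=O)C2` has not yet been measured. It differs from compound 1 in one place: fluoro in place of methoxy on an aromatic carbon. The step from compound 1 to compound 2 bears on this change only indirectly, since it too alters the group on the aromatic nitrogen, and it shows that such an exchange shifted the number by no more than the scatter. Within the data shown here, no measured pair sets fluoro directly against methoxy. The expectation for compound 3 in this assay is therefore no step beyond the scatter, a 1.3-fold lower number from compound 1 to compound 3 (0.10 log units; within the scatter). Compound 3 is estimated at 200 nM, with a range from 90 nM to 450 nM.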

Compound 3, half-maximal inhibitory concentration: 200 nM
Compound 3: middle estimate and measured number agree at the digits printed; the range from low to high includes it.
By their numbers in this assay, from the lowest: compounds 2, 3 and 1 (each within the scatter of the next).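

In this assay, the exchange of methoxy for fluoro on an aromatic carbon, para to a large group, now has a direct reading: a 1.3-fold lower number from compound 1 to compound 3 (0.10 log units; within the scatter). This step shows that these two groups cannot be told apart at this position, whereas the earlier step had spoken to the change only indirectly. The second new step, a 1.4-fold higher number from compound 2 to compound 3 (0.15 log units; within the scatter), is also within the scatter, so 4-fluorophenyl, 2-bromophenyl and 4-methoxyphenyl on the aromatic nitrogen of the shared core cannot be ranked against one another, and nothing available explains why these numbers lie so close together.

What the compounds shown leave open is whether any group at this position can move the number beyond the scatter, since an amine, a carboxylic acid or a longer chain such as butoxy in place of methoxy remains untested among them. Also open, from the compounds shown here alone, is how the number would read with a plain phenyl on the aromatic nitrogen, with no group on the ring at all.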